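Heteroaryl in place of fluorophenyl on the ring amine

The source may report more compounds than this note shows. Statements on the series, on what has been measured and on what is new or still open speak of the compounds shown alone.

Compound 1 `O=C(CN1CCN(c2cccc(F)c2)CC1)Nc1nc2c(s1)CCCC2` stands on a limit in an assay on isolated protein for inhibition of long-chain fatty acid transport protein 1 (Homo sapiens), read by scintillation counting, with a stated time of 20 min; a lower number here means a stronger inhibitor, a higher number a weaker inhibitor: it gives > 1000 nM, which is a limit of the assay and not a number. This is the limit of > 1000 nM in this assay, at which 1 of the 3 values shown sits. Compound 2 `O=C(CN1CCN(c2ccc(F)cc2)CC1)Nc1nc2ccccc2s1` gives 490 nM in this assay. Compound 3 `Cc1nc(NC(=O)CN2CCN(c3ccc(F)cc3)CC2)sc1C` gives 430 nM in this assay, and compounds 2 and 3 lie within the scatter of each other. Compound 4 `O=C(CN1CCN(c2nccs2)CC1)Nc1nc2c(s1)CCCC2` carries the change (1,3-thiazol-2-yl in place of 3-fluorophenyl on an amine nitrogen in a ring). For the measured compounds named here, no step between measured compounds covers this change, and compound 1 has only a limit, so the size of the step is open; a move in either direction beyond the scatter cannot be excluded, and a weak value for compound 4 remains the likelier outcome. Compound 4 is expected near 1500 nM, within 500 nM to 5000 nM, which as an estimate means a step that the limit leaves unreadable from compound 1 to compound 4.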

Compound 4, half-maximal inhibitory concentration: 520 nM
Compound 4: the middle estimate sits 2.9-fold (0.46 log units) above what was measured; the measured number falls inside the stated range.
By their numbers in this assay, from the lowest: compounds 3, 2 and 4 (each within the scatter of the next). At a limit, above all of these: compound 1.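

Compound 1 gives > 1000 nM in this assay, a limit and not a number. With 1,3-thiazol-2-yl in place of 3-fluorophenyl on the amine nitrogen in the ring, the shared core gives a measured number, and the step reads an at least 1.9-fold lower number from compound 1 to compound 4 (0.28 log units; that floor lies within the scatter). The full size of this step stays unreadable because one end of it is a limit: the limit of > 1000 nM in this assay, at which 1 of the 4 values shown sits.

On these data alone, whether an unsubstituted phenyl or a pyridin-2-yl on the same nitrogen also gives a measured number remains open. So does whether 1,3-thiazol-2-yl behaves alike on the cores of compound 2 and compound 3.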